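From 4-hydroxyphenyl to 2,4,6-trihydroxyphenyl

This account rests on a few compounds, and the source may have more. Where it says the series, first, only, none or still open, it means among the compounds named here.

Among the measured compounds shown here, only two related compounds have been measured so far in a functional assay on DU-145 cells (Homo sapiens) for inhibition, read by trypan blue exclusion, with a stated time of 96 h; on this read-out lower numbers stand for stronger inhibition of growth and higher numbers for weaker inhibition of growth. Compound 1 (`Cc1ccc(CS/C(=C/c2ccc(O)cc2)C(=O)c2ccc(Cl)cc2)cc1`) gives 10000 nM, the higher of the two numbers and so the weaker inhibition of growth. Compound 2 (`O=C(/C(=C\c1cc(Cl)cc(Cl)c1Cl)S(=O)(=O)Cc1ccc(Cl)cc1)c1ccc(Br)cc1`) gives 1000 nM, and this gap lies beyond the usual scatter of repeated measurements.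

Compound 3 (`Cc1ccc(CS/C(=C/c2c(O)cc(O)cc2O)C(=O)c2ccc(Cl)cc2)cc1`) has not yet been measured. It keeps the core of compound 1 and changes one group, with 2,4,6-trihydroxyphenyl in place of 4-hydroxyphenyl on a double-bonded chain carbon bound to a double-bonded chain carbon.

The two measured compounds differ in more than one place, so the data offer no direct guide to this step. For the measured compounds named here, with compound 1 at 10000 nM, the higher number so far, a modest shift toward stronger inhibition is the tentative expectation, but a result no different from compound 1 would not surprise. The expected change is a 2.5-fold lower number from compound 1 to compound 3 (0.40 log units; beyond the scatter). For compound 3 the estimated value is 4000 nM, with an expected range from 600 nM to 20000 nM.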

Compound 3, concentration for 50% growth inhibition: 50000 nM
Beside the measured number, compound 3's estimate is 13-fold (1.10 log units) below it; measured number above the stated range.
By their numbers in this assay, from the lowest: compound 2; then compound 1; then compound 3.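

Among the compounds shown here, this step gives the first direct reading at this position, on a double-bonded chain carbon bound to a double-bonded chain carbon. In this assay, placing 2,4,6-trihydroxyphenyl where 4-hydroxyphenyl stood gives a 5.0-fold higher number from compound 1 to compound 3 (0.70 log units; beyond the scatter), so inhibition of growth becomes weaker rather than stronger, and the position is shown to be sensitive to a change in this aromatic group. The measurements shown do not explain why the extra hydroxyl groups come with weaker inhibition.

As far as these compounds go, since the extra hydroxyl groups enter together, it remains open whether the change comes from one of them alone or only from the full set. Also open, from the compounds shown here alone, is how this position would respond if the 4-hydroxyphenyl were replaced by a plain phenyl or if its hydroxyl gave way to a methoxy, an amine or a carboxylic acid, and such compounds would help show whether any hydroxyl is needed here at all.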